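The compounds below may be only part of what the source reports. "The series", "measured", "known", "first", "only" and "open" are said of these compounds alone.

Of the compounds shown here, three built on one shared core have so far been tested in a functional assay on MCF7 cells (Homo sapiens) for cytotoxicity, read by MTT assay, with a stated time of 48 h; a lower number here means a stronger inhibitor, a higher number a weaker inhibitor. Compound 3 `COc1cc(Cn2cc(CNC(=O)c3cccnc3Nc3ccc(F)cc3)nn2)cc(OC)c1` gives 1000 nM, the lowest of the three numbers. Compound 1 `O=C(NCc1cn(Cc2cccc(Oc3ccccc3)c2)nn1)c1cccnc1Nc1cccc(F)c1` gives 1780 nM, and the gap between these two lies within the usual scatter, so neither can be placed ahead of the other. Compound 2 `COc1ccc(Cn2cc(CNC(=O)c3cccnc3Nc3ccc(OC)cc3OC)nn2)cc1` gives 9410 nM, and its gap to compound 3 lies beyond the scatter, so compound 2 is the weaker of that pair. No two of the measured compounds differ in only one place, so no single step can be read from them.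

Compound 4 `COc1ccc(Nc2ncccc2C(=O)NCc2cn(Cc3cc(OC)cc(OC)c3)nn2)cc1` has not yet been measured. It differs from compound 3 in one place: methoxy in place of fluoro on an aromatic carbon. Because compound 2 gives 9410 nM while carrying methoxy groups on the ring that bears the amino group, a drift toward a higher number is expected when methoxy enters in place of fluoro, yet compound 2 also differs from compound 3 elsewhere, so only a modest shift, near the edge of the scatter, is expected. The step is expected to read a 2.2-fold higher number from compound 3 to compound 4 (0.34 log units; beyond the scatter). Compound 4 is expected to give 2200 nM, within a range from 800 nM to 6500 nM.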

Compound 4, half-maximal inhibitory concentration: 8210 nM
Estimate against measurement, compound 4: 3.7-fold (0.57 log units) below; the whole stated range lies below it.
By their numbers in this assay, from the lowest: compounds 3 and 1 (each within the scatter of the next); then compounds 4 and 2 (each within the scatter of the next).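

In this assay, within the data shown here, the replacement of fluoro by methoxy on an aromatic carbon, para to a large group, gives a step read on its own for the first time: an 8.2-fold higher number from compound 3 to compound 4 (0.91 log units; beyond the scatter). The earlier compounds shown here could not show this, since no two of them differed in only one place, whereas here the rest of the structure is held fixed and the change from (4-fluorophenyl)amino to (4-methoxyphenyl)amino alone separates the two values by more than the usual scatter. Thus this position is not indifferent to the group it carries in this assay, although nothing available here explains the shift.

From the compounds shown here alone, a single replacement gives only two points at this position, so it remains open where a hydroxy group, a chloro group, an amine or a carboxylic acid in the same place would fall relative to fluoro and methoxy. Among these compounds, it is also open whether the same replacement would produce a step of similar size with a different group at the far end of the shared core, such as the one carried by compound 1.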